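The source may hold more compounds than are shown below. What is called first, only, known or untested is meant among the compounds shown, and "the series" means these compounds.

Measured so far:
compound 1 `CCC(c1ccc(-c2cscc2C)cc1)n1ccnc1` — 27%
compound 2 `CCC(c1ccc(-c2ccsc2)cc1)n1ccnc1` — 28%

Both were tested in an assay for inhibition of steroid 17-alpha-hydroxylase/17,20 lyase (Homo sapiens), using NADPH, tested at 0.2 uM; on this read-out lower numbers stand for a weaker effect and higher numbers for a stronger effect at the one concentration tested. Compound 2 stands highest of the two numbers, but only by a number 1 percentage points higher from compound 1 to compound 2 (within the scatter), so the two compounds cannot be told apart on this read-out. That step swapped a hydrogen for a methyl on an aromatic carbon of the shared core and changed nothing beyond the scatter.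

Compound 3 `CCC(c1ccc(-c2ccsc2Cl)cc1)n1ccnc1` has not yet been measured. It differs from compound 2 by chloro in place of hydrogen on an aromatic carbon, a single heavy atom entering next to the ring sulfur. Among the compounds with values here, the one step seen so far, a small group exchanged on the same five-membered ring, moved the number by a number 1 percentage points higher from compound 1 to compound 2 (within the scatter). On that basis the expected step of a number 2 percentage points higher from compound 2 to compound 3 (within the scatter) is none beyond the scatter. Compound 3 is therefore estimated at 30%, with a likely range from 15% to 45%.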

Compound 3, a percentage reported as inhibition, at one concentration (the size of the read-out at that concentration, not a potency): 40%
Beside the measured number, compound 3's estimate is 10 percentage points below it, within the range that was stated.
By their numbers in this assay, from the lowest: compounds 1 and 2 (each within the scatter of the next); then compound 3.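

Unlike the earlier exchange on this ring, this change moves the read-out: in this assay chloro in place of hydrogen, next to the ring sulfur, gives a number 12 percentage points higher from compound 2 to compound 3 (beyond the scatter) and so shows that this aromatic carbon is a place where a substituent can make a modest difference. The comparison with the methyl-bearing compound agrees, with 2-chlorothiophen-3-yl in place of 4-methylthiophen-3-yl giving a number 13 percentage points higher from compound 1 to compound 3 (beyond the scatter) even though that swap alters two places on the ring. Nothing available explains this gain.

Going by these compounds, whether the gain is specific to chloro remains open, since bromo, methoxy or an amine on the same carbon could give a similar, larger or smaller number. The read-out also comes from one concentration, so it shows a stronger effect at that concentration and nothing more.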